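Methoxyphenyl in Place of Chlorophenyl: Expected Potency

This account rests on a few compounds, and the source may have more. Where it says the series, first, only, none or still open, it means among the compounds named here.

Measured so far in a functional assay on MCF7 cells (Homo sapiens) for inhibition, read by sulforhodamine B assay, with a stated time of 48 h; a lower number here means a stronger inhibitor, a higher number a weaker inhibitor:
compound 1 `CSc1nn(-c2ccccc2)c2ncnc(N/N=C/c3ccc(Br)cc3)c12`: 10.9 nM
compound 2 `CSc1nn(-c2ccccc2)c2ncnc(N/N=C/c3ccc(Cl)cc3)c12`: 12.1 nM
compound 3 `CSc1nn(-c2ccccc2)c2ncnc(N/N=C/c3ccc(O)cc3)c12`: 10.3 nM

The three compounds share one core and differ only in the group carried on the aromatic ring attached to the carbon with a double bond to nitrogen. Compound 2 gives the highest of the three numbers, but its neighbours sit close: a 1.1-fold higher number from compound 1 to compound 2 (0.05 log units; within the scatter), and a 1.2-fold lower number from compound 2 to compound 3 (0.07 log units; within the scatter), while a 1.1-fold lower number from compound 1 to compound 3 (0.02 log units; within the scatter). None of these moves goes beyond the scatter, so on the numbers shown the three compounds cannot be told apart.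

Compound 4 `COc1cccc(/C=N/Nc2ncnc3c2c(SC)nn3-c2ccccc2)c1` has not been measured. It differs from compound 2 by 3-methoxyphenyl in place of 4-chlorophenyl on a carbon with a double bond to nitrogen. The measured steps concern swaps of bromo, chloro and hydroxy on that same ring, and each was flat; they bear on compound 4 only by showing that this ring accepts several different groups without a shift in this assay. Among the compounds with values here, a methoxy group, and its different placement on the ring, have no measured counterpart here, so the expected step from compound 2 to compound 4 is small, a 1.2-fold higher number from compound 2 to compound 4 (0.09 log units; within the scatter), with a wider band of doubt than usual. Compound 4 is therefore estimated at 15 nM, within 5 nM to 45 nM.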

Compound 4, half-maximal inhibitory concentration: 11.1 nM
Compound 4: the middle estimate sits 1.4-fold (0.13 log units) above what was measured; the measured number falls inside the stated range.
By their numbers in this assay, from the lowest: compounds 3, 1, 4 and 2 (each within the scatter of the next).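

In this assay, the swap of 4-chlorophenyl for 3-methoxyphenyl changes both the group on the ring and its placement, and the result is still flat, with a 1.1-fold lower number from compound 2 to compound 4 (0.04 log units; within the scatter) and no shift beyond the scatter. Within the data shown here, the comparisons with the other two measured compounds agree, with a 1.1-fold higher number from compound 3 to compound 4 (0.03 log units; within the scatter) and a 1.0-fold higher number from compound 1 to compound 4 (0.01 log units; within the scatter), so this position, until now seen only with bromo, chloro and hydroxy in a single placement, also accepts a methoxy group in a different placement without a change that can be told from the scatter. Nothing measured here explains why these four compounds cannot be told apart in this assay.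

Among the compounds shown, the effect of the new group and the effect of its new placement cannot be separated, since both change in the same step. As far as these compounds go, it also remains open whether this tolerance extends to quite different groups on this ring, such as an amine, a carboxylic acid or a longer chain.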